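This account rests on a few compounds, and the source may have more. Where it says the series, first, only, none or still open, it means among the compounds named here.

In a functional assay on Bel-7402 cells (Homo sapiens) for cytotoxicity, read by sulforhodamine B assay, with a stated time of 24 h (on this read-out lower numbers stand for stronger inhibition and higher numbers for weaker inhibition), compound 3 `C=CC(C)(C)c1[nH]c2ccccc2c1/C=C1\NC(=O)C(C)(OC)NC1=O` gives only > 50000 nM, which is a limit of the assay and not a number. Compound 1 `C=CC(C)(C)c1[nH]c2ccc(C[C@@H](O)C(=C)C)cc2c1/C=C1\NC(=O)[C@H](C)NC1=O` likewise gives only the limit > 50000 nM. Compound 2 `C=CC(C)(C)c1[nH]c2ccc(CC(=O)C(C)C)cc2c1/C=C1\NC(=O)[C@H](C)NC1=O` gives the limit > 50000 nM as well. Within the data shown here, the one step between measured compounds that differ in a single place, a step that the two limits leave unreadable from compound 1 to compound 2, is therefore unreadable, and it offers no scale for any change. Compound 4 `C=CC(C)(C)c1[nH]c2ccc(CC=C(C)C)cc2c1/C=C1\NC(=O)C(C)(OC)NC1=O` differs from compound 3 by 3-methylbut-2-en-1-yl in place of hydrogen on an aromatic carbon. Among the measured compounds shown here, no measured step bears directly on this change; what the three values have in common is the limit of > 50000 nM in this assay, at which 3 of the 3 values shown sit, and nothing measured points away from that limit. The writer therefore expects compound 4 to remain at or near the same limit, with an expected step that the limit leaves unreadable from compound 3 to compound 4 that would not exceed the scatter. The estimate for compound 4 in this assay is 60000 nM, with a range from 20000 nM to 200000 nM, and it is expected that the assay will most likely again report only a limit.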

Compound 4, half-maximal inhibitory concentration: > 50000 nM
Compound 4: a limit, no number (the forecaster's own chance of this, stated with the estimate: 80%); the middle value lies beyond the limit too.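

Compound 3 and compound 4 both give only a limit, so the step from one to the other cannot be read, and 3-methylbut-2-en-1-yl in place of hydrogen on an aromatic carbon has no measurable size here. The compounds shown leave open whether any change to the shared core brings a readable value: the limit of > 50000 nM in this assay, at which 4 of the 4 values shown sit.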